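The source may hold more compounds than are shown below. What is called first, only, known or untested is meant among the compounds shown, and "the series" means these compounds.

Measured in a functional assay on DU-145 cells (Homo sapiens) for antiproliferative activity, read by MTT assay, with a stated time of 72 h (a higher number here means a weaker inhibitor, a lower number a stronger inhibitor), so far:
- compound 1 `COc1cc2c(Nc3ccc(C#N)cc3)ncnc2cc1OCCCN(C)C` gives 35300 nM
- compound 2 `COc1cc2c(Nc3ccc(C#N)cc3)ncnc2cc1OCCCN1CCC(O)CC1` gives 74900 nM
- compound 3 `COc1cc2c(Nc3ccc(C#N)cc3)ncnc2cc1OCCCN1CCCCC1CCO` gives > 100000 nM (a limit)

Compound 3 has no number in this assay and stands only at its limit (> 100000 nM). Compound 4 `COc1cc2c(Nc3ccc(C#N)cc3)ncnc2cc1OCCCN1CCN(C)CC1` differs from compound 3 by one change (4-methylpiperazin-1-yl in place of 2-(2-hydroxyethyl)piperidin-1-yl on a saturated chain carbon, three bonds along the chain from an oxygen on an aromatic ring) in which 4-methylpiperazin-1-yl replaces 2-(2-hydroxyethyl)piperidin-1-yl on a saturated chain carbon, three bonds along the chain from an oxygen on an aromatic ring.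

Three measured steps changed the amine at this same place. Two were modest or at least modest (a 2.1-fold higher number from compound 1 to compound 2 (0.33 log units; beyond the scatter)) (an at least 2.8-fold higher number from compound 1 to compound 3 (0.45 log units; beyond the scatter)). The third has a floor within the scatter (an at least 1.3-fold higher number from compound 2 to compound 3 (0.12 log units; that floor lies within the scatter)). Going by the values given here, the only numbers at this place so far are from compound 1 (35300 nM) and compound 2 (74900 nM), and compound 4 is expected to fall near them.

A modest step to a lower number is therefore expected (an at least 2.0-fold lower number from compound 3 to compound 4 (0.30 log units; that floor lies within the scatter)). The estimate for compound 4 is 50000 nM, with an expected range of 20000 nM to 100000 nM.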

Compound 4, half-maximal inhibitory concentration: 46500 nM
Estimate against measurement, compound 4: 1.1-fold (0.03 log units) above, and the stated range covers the measured number.
By their numbers in this assay, from the lowest: compounds 1, 4 and 2 (each within the scatter of the next, the first and the last beyond it). At a limit, above all of these: compound 3.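

In this assay, going by these compounds alone, an at least 2.1-fold lower number from compound 3 to compound 4 (0.33 log units; beyond the scatter) is the first step at this place, on a saturated chain carbon, three bonds along the chain from an oxygen on an aromatic ring, that runs to a lower number. On these data alone, compound 3 is held only at a limit, so that step is a floor and its true size stays unknown: the limit of > 100000 nM in this assay, at which 1 of the 4 values shown sits. Both a 1.6-fold lower number from compound 2 to compound 4 (0.21 log units; within the scatter) and a 1.3-fold higher number from compound 1 to compound 4 (0.12 log units; within the scatter) lie within the scatter, so 4-methylpiperazin-1-yl cannot be told apart from either 4-hydroxypiperidin-1-yl or dimethylamino, although those two groups are separated beyond the scatter.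

As far as these compounds go, whether the 2-hydroxyethyl branch itself goes with the limit of compound 3 stays open, and an unsubstituted piperidin-1-yl at this place would address that. Also open, from the compounds shown here alone, is whether a morpholin-4-yl group or a longer chain would move the number clearly away from this cluster.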